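Halogen pattern on the anilino ring: compound 3 outlook

The source may report more compounds than this note shows. Statements on the series, on what has been measured and on what is new or still open speak of the compounds shown alone.

Measured so far:
compound 1, `CN1CCN(CCCOc2cccc3nc(Nc4ccc(Cl)c(F)c4)ccc23)CC1`, a functional assay on A549 cells (Homo sapiens) for inhibition, read by sulforhodamine B assay, with a stated time of 48 h (on this read-out higher numbers stand for weaker inhibition of growth and lower numbers for stronger inhibition of growth), 1960 nM
compound 2, `CN1CCN(CCCOc2cccc3nc(Nc4ccc(F)c(F)c4)ccc23)CC1`, this assay 3500 nM

Within the data shown here, compound 2 holds the higher of the two numbers, but its only neighbour, compound 1, sits within the scatter: a 1.8-fold higher number from compound 1 to compound 2 (0.25 log units; within the scatter). No order between the two can be claimed.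

Compound 3, `CN1CCN(CCCOc2cccc3nc(Nc4cc(Cl)cc(Cl)c4)ccc23)CC1`, is not yet measured. The change is 3,5-dichlorophenyl in place of 3,4-difluorophenyl on a nitrogen on an aromatic ring. Among the measured compounds shown here, only the step from compound 1 to compound 2 bears on it, and only loosely: it covers the exchange of one chloro for one fluoro at a single place and stayed within the scatter, whereas here both halogens and their pattern on the ring change at once. For the measured compounds named here, no measured step covers that pattern. In this assay compound 3 is therefore expected near compound 2, and the expected step of a 1.4-fold lower number from compound 2 to compound 3 (0.15 log units; within the scatter) is not expected to exceed the scatter with confidence. Compound 3 is estimated at 2500 nM, with a range from 800 nM to 8000 nM.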

Compound 3, concentration for 50% growth inhibition: 1980 nM
Compound 3: the middle estimate sits 1.3-fold (0.10 log units) above what was measured, within the range that was stated.
By their numbers in this assay, from the lowest: compounds 1, 3 and 2 (each within the scatter of the next).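

In this assay, among these compounds, 3,5-dichlorophenyl in place of 3,4-difluorophenyl on a nitrogen on an aromatic ring gives a 1.8-fold lower number from compound 2 to compound 3 (0.25 log units; within the scatter), so changing both halogens and their pattern at once stays inside the scatter, as the single exchange of chloro for fluoro did. In place of 4-chloro-3-fluorophenyl, the same group gives a 1.0-fold higher number from compound 1 to compound 3 (0.00 log units; within the scatter), so the three halogen patterns shown cannot be told apart at this position. No measurement on hand accounts for these numbers lying so close together.

Still open, from the compounds shown here alone, is whether an unsubstituted phenyl, or a ring carrying methoxy or trifluoromethyl in place of the halogens, would move the number beyond the scatter. Equally open, going by these compounds, is whether a morpholine at the end of the side chain of the shared core would do so.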